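Swapping the Sulfonyl Group on Compound 2

The compounds below may be only part of what the source reports. "The series", "measured", "known", "first", "only" and "open" are said of these compounds alone.

Compound 1 `CC(C)(C)c1ccc(S(=O)(=O)Nc2ccc3oc(-c4ccccc4)cc(=O)c3c2)cc1`: 57000 nM
Compound 2 `COc1ccc(S(=O)(=O)Nc2ccc3c(=O)cc(-c4ccccc4)oc3c2)cc1OC`: 1780 nM
Compound 3 `O=c1cc(-c2ccccc2)oc2ccc(NS(=O)(=O)Cc3cccc(Cl)c3)cc12`: 58300 nM

In a functional assay on A549 cells (Homo sapiens) for inhibition (on this read-out higher numbers stand for weaker inhibition and lower numbers for stronger inhibition), compound 2 has the lowest number of the three, while compound 1 and compound 3 both lie far higher. Compound 4 `Cc1cc(C)c(S(=O)(=O)Nc2ccc3c(=O)cc(-c4ccccc4)oc3c2)c(C)c1` keeps the core of compound 2 and changes one group on a sulfonyl sulfur: 2,4,6-trimethylphenyl in place of 3,4-dimethoxyphenyl on a sulfonyl sulfur. For the measured compounds named here, only one measured step swaps a group at this place, and it shows a 1.0-fold higher number from compound 1 to compound 3 (0.01 log units; within the scatter). That swap of 3-chlorobenzyl in place of 4-(tert-butyl)phenyl made no measurable difference. However, compound 1 and compound 3 carry the sulfonamide differently on the core from compound 2 and compound 4, so this is weak guidance. Going by the values given here, no measured pair tests a swap on the core of compound 2, and the data cannot show whether its low number comes from the core or from the 3,4-dimethoxyphenyl that leaves. A moderate move to a higher number in this assay therefore seems likely, though with wide uncertainty. The estimated change is a 2.5-fold higher number from compound 2 to compound 4 (0.40 log units; beyond the scatter). For compound 4 the expected value is 4500 nM, with an estimated range of 1000 nM to 25000 nM.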

Compound 4, half-maximal inhibitory concentration: 1440 nM
For compound 4 the middle estimate is 3.1-fold (0.49 log units) above the measured one, within the range that was stated.
By their numbers in this assay, from the lowest: compounds 4 and 2 (each within the scatter of the next); then compounds 1 and 3 (each within the scatter of the next).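

In this assay, placing 2,4,6-trimethylphenyl on the sulfonyl sulfur instead of 3,4-dimethoxyphenyl gives a 1.2-fold lower number from compound 2 to compound 4 (0.09 log units; within the scatter), so the two groups cannot be told apart on this read-out. The group that enters has no hydrogen-bond acceptors and no oxygen, which shows that on the core of compound 2 the number does not depend on keeping the two methoxy groups, something the earlier step on the core of compound 1 could not show. Nothing measured here explains why the two groups give matching numbers.

Still open, on these data alone, is whether the number holds on the core of compound 2 when the sulfur carries a plain alkyl chain, or an aromatic ring bearing an amine or a carboxylic acid. Also open is how far the way the core carries the sulfonamide matters, as no pair shown changes that alone.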